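This account rests on a few compounds, and the source may have more. Where it says the series, first, only, none or still open, it means among the compounds named here.

Series notes. Compound 1 `O=C1/C(=C\c2ccc(O)cc2)c2ccccc2N1c1c(Cl)cccc1Cl` and compound 2 `O=C1/C(=C\c2cccc(Br)c2)c2ccccc2N1c1c(Cl)cccc1Cl` share the core and differ only in the aryl group on the double-bonded chain carbon bound to a double-bonded ring carbon. In a functional assay on HuTu80 cells (Homo sapiens) for cytotoxicity, read by MTT assay, with a stated time of 72 h (on this read-out lower numbers stand for an effect already at smaller amounts and higher numbers for an effect only at larger amounts of compound), compound 1 gives 25 ug/mL. In this assay compound 2 gives 7 ug/mL. Among the measured compounds shown here, the only measured step in the set is a 3.6-fold lower number from compound 1 to compound 2 (0.55 log units; beyond the scatter). Compound 2 therefore holds the lowest of the two numbers, with compound 1 the nearest and higher.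

Compound 3 `O=C1/C(=C\c2ccccc2[N+](=O)[O-])c2ccccc2N1c1c(Cl)cccc1Cl` is the next member. Its change from compound 2 is 2-nitrophenyl in place of 3-bromophenyl on a double-bonded chain carbon bound to a double-bonded ring carbon. For the measured compounds named here, no measured step involves a nitrophenyl group; the one step on record, a 3.6-fold lower number from compound 1 to compound 2 (0.55 log units; beyond the scatter), swapped a 4-hydroxyphenyl for a 3-bromophenyl and was modest in size, so it offers no direct guide for the new aryl group. The expectation for compound 3 is accordingly a step of a 1.4-fold higher number from compound 2 to compound 3 (0.15 log units; within the scatter) in this assay, which is no clear shift beyond the scatter, with a wide range around it. Compound 3 is expected to give 10 ug/mL, within 4 ug/mL to 25 ug/mL.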

Compound 3, concentration for half-maximal effect: 10 ug/mL
Estimate against measurement, compound 3: no gap at the digits printed; low and high end bracket the measured number.
By their numbers in this assay, from the lowest: compounds 2 and 3 (each within the scatter of the next); then compound 1.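

In this assay, replacing the 3-bromophenyl with a 2-nitrophenyl on the double-bonded chain carbon gives a 1.4-fold higher number from compound 2 to compound 3 (0.15 log units; within the scatter), so the two aryl groups cannot be told apart here, even though the entering group differs in its atoms and carries 2 hydrogen-bond acceptors where the leaving group has 0. The other new step, a 2.5-fold lower number from compound 1 to compound 3 (0.40 log units; beyond the scatter), shows that a second aryl group also stands apart from the 4-hydroxyphenyl of compound 1, so the earlier drop is no longer tied to the 3-bromophenyl alone. Nothing available bears on why the numbers fall this way.

The three aryl groups differ both in the substituent and in where it sits on the ring, so the compounds shown cannot separate these two changes. Also open, as far as these compounds go, is how an unsubstituted phenyl, an aminophenyl or a phenyl bearing a carboxylic acid would read at this position on the shared core, and whether the 4-hydroxyphenyl stands alone or belongs to a wider group of aryl substituents with higher numbers.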